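Piperazinone indole carboxamide series: half-life in liver microsomes

The compounds below may be only part of what the source reports. "The series", "measured", "known", "first", "only" and "open" are said of these compounds alone.

Measured compounds:
compound 1 `COc1ccc2[nH]c(C(=O)N3CC(=O)N(Cc4ccccc4)[C@@H](CCc4ccccc4)C3)cc2c1` — 0.167 h
compound 2 `COc1cccc(CN2C(=O)CN(C(=O)c3cc4cc(OC)ccc4[nH]3)C[C@@H]2c2ccccc2)c1` — 0.118 h
compound 3 `COc1ccc2[nH]c(C(=O)N3CC(=O)N(Cc4ccccc4)[C@@H](N4CCc5ccccc54)C3)cc2c1` — 0.25 h

In an ADME assay on microsomes from liver (Homo sapiens) for metabolic stability, with a stated time of 30 min, tested at 1 uM (a lower number here means that the compound disappears faster, a higher number that the compound lasts longer), compound 1 gives 0.167 h, the second highest of the three numbers. Compound 2 gives 0.118 h and compound 3 gives 0.25 h; both lie within the scatter of compound 1, so no order among the three can be claimed.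

Compound 4 `COc1ccc2[nH]c(C(=O)N3CC(=O)N(Cc4ccccc4)[C@@H](CN4CC5CC5C4)C3)cc2c1` is not yet measured. It differs from compound 1 as follows: a group of 6 heavy atoms (5 carbon, 1 nitrogen; one three-membered non-aromatic ring of carbon only, one five-membered non-aromatic ring with 1 hetero atom) in place of a group of 7 heavy atoms (7 carbon; one six-membered aromatic ring of carbon only), on a saturated chain carbon bound to a saturated ring carbon.

Among the measured compounds shown here, only one measured step bears on it, and only loosely: a 1.5-fold higher number from compound 1 to compound 3 (0.18 log units; within the scatter). For the measured compounds named here, that step alters the group on the saturated ring carbon, whereas the change to compound 4 sits on the chain carbon bound to that ring carbon, and no pair in the set varies the benzyl group itself. What the series shows is that a change of comparable size at a neighbouring place moved the number by less than the scatter.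

On that basis the step from compound 1 to compound 4 is expected to stay within the scatter, a 1.2-fold higher number from compound 1 to compound 4 (0.08 log units; within the scatter). The estimate for compound 4 in this assay is 0.2 h, with a range from 0.1 h to 0.45 h.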

Compound 4, half-life: 0.35 h
Beside the measured number, compound 4's estimate is 1.8-fold (0.24 log units) below it; low and high end bracket the measured number.
By their numbers in this assay, from the lowest: compounds 2, 1, 3 and 4 (each within the scatter of the next, the first and the last beyond it).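

In this assay, among the compounds shown here, the step at the saturated chain carbon bound to a saturated ring carbon, where the benzyl group gives way to the non-aromatic group holding a three-membered ring of carbon only and a five-membered ring with 1 hetero atom, is a 2.1-fold higher number from compound 1 to compound 4 (0.32 log units; beyond the scatter); it is the first step to pass the scatter, whereas a 1.5-fold higher number from compound 1 to compound 3 (0.18 log units; within the scatter), with 2,3-dihydro-1H-indol-1-yl in place of phenethyl on a saturated ring carbon, did not. The two non-aromatic and partly aromatic amine-bearing replacements are not separated from each other, since a 1.4-fold higher number from compound 3 to compound 4 (0.15 log units; within the scatter) stays within the scatter, and compound 3 and compound 4 cannot be ordered. No measurement in hand accounts for the difference between compound 1 and compound 4.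

The change removes the aromatic ring and brings in the nitrogen and its hydrogen-bond acceptor in a single step, so the share of each remains unresolved. A carbon-only cyclohexyl group or a simple piperidine at the same place would be needed to pull these apart, and the step rests on single values close to the edge of the scatter.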